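The source may report more compounds than this note shows. Statements on the series, on what has been measured and on what is new or still open speak of the compounds shown alone.

Compound 2 `COc1cc(OC)c(-c2coc3cc(OCc4ccccc4F)ccc3c2=O)cc1OC` was tested in a functional assay on B16 cells (Mus musculus) for antiproliferative activity, read by MTT assay, with a stated time of 24 h (on this read-out higher numbers stand for weaker inhibition and lower numbers for stronger inhibition), where compound 2 gives 1610 nM. Within the data shown here, its only measured neighbour, compound 1 `COc1ccc2c(=O)c(-c3cc(OC)c(OC)cc3OC)coc2c1`, gives 5200 nM in this assay, so compound 2 stands at the lowest of the two numbers, and the step of a 3.2-fold lower number from compound 1 to compound 2 (0.51 log units; beyond the scatter) is the single measured step in hand. Compound 3 `COc1cc(OC)c(-c2coc3cc(OCc4cccc(F)c4)ccc3c2=O)cc1OC` has not yet been measured. It differs from compound 2 by 3-fluorophenyl in place of 2-fluorophenyl on a saturated chain carbon bound to an oxygen on an aromatic ring. Among the measured compounds shown here, the step from compound 1 to compound 2 introduced the 2-fluorophenyl as a whole; no measured step exchanges one fluorophenyl for another, so that step bears on the present change only indirectly, showing that a fluorophenyl at this place is tolerated. For the measured compounds named here, with no step of the same kind measured, no move beyond the scatter is expected in this assay. Compound 3 is therefore estimated at 1600 nM, between 700 nM and 3600 nM. The expected step is a 1.0-fold lower number from compound 2 to compound 3 (0.00 log units; within the scatter).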

Compound 3, half-maximal inhibitory concentration: 2440 nM
Estimate against measurement, compound 3: 1.5-fold (0.18 log units) below; the measured number falls inside the stated range.
By their numbers in this assay, from the lowest: compounds 2 and 3 (each within the scatter of the next); then compound 1.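

In this assay the exchange of 2-fluorophenyl for 3-fluorophenyl is a 1.5-fold higher number from compound 2 to compound 3 (0.18 log units; within the scatter) and so does not separate the two groups at this position. The 3-fluorophenyl also holds a real difference from the compound without a fluorophenyl, with a 2.1-fold lower number from compound 1 to compound 3 (0.33 log units; beyond the scatter) on record, so the gain seen with the 2-fluorophenyl is not tied to that one fluorophenyl alone. No measurement is at hand that explains these numbers.

The compounds shown leave open whether a plain benzyl without fluorine or a chlorobenzyl would give a similar number at this place, so the contribution of the fluorine itself remains unknown. From the compounds shown here alone, it also remains open whether an aromatic ring is needed here at all, or whether a longer chain or an amine on the same oxygen would serve as well.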